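The compounds below may be only part of what the source reports. "The series", "measured", "known", "first", "only" and "open" are said of these compounds alone.

Series notes, cytotoxicity on mouse microglial cells.

Compound 1 `COc1ccccc1S(=O)(=O)/C=C/c1ccccn1` is the unsubstituted reference. In an ADME assay on BV-2 cells (Mus musculus) for cytotoxicity, with a stated time of 24 h, tested at 50 uM (on this read-out lower numbers stand for a stronger effect and higher numbers for a weaker effect at the one concentration tested), compound 1 gives 100%. Compound 2 `COc1ccccc1S(=O)(=O)/C=C/c1cccc(Cl)n1` carries the change (chloro in place of hydrogen on an aromatic carbon), and in this assay compound 2 gives 80.5%. The step of a number 19.5 percentage points lower from compound 1 to compound 2 (beyond the scatter) is the only measured effect of a substituent so far.

Compound 3 `COc1cccc(S(=O)(=O)/C=C/c2ccccn2)c1` has the same atoms as compound 1 joined differently; the difference between the two cores is not broken down here. In this assay compound 3 gives 98.9%, which sits within the scatter of compound 1 and well apart from compound 2.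

Compound 4 `COc1cccc(S(=O)(=O)/C=C/c2ccc(Cl)cn2)c1` is built on the core of compound 3 and carries the change (chloro in place of hydrogen on an aromatic carbon). This is the same kind of change as in compound 2, not the same change: in compound 2 the chloro sits next to the ring nitrogen, meta to a large group, whereas in compound 4 it sits two atoms from the ring nitrogen, para to a large group. Among the compounds with values here, only one such step has been measured, and on a different core, so the transfer is uncertain.

Within the data shown here, for compound 4 the expected step is a number 16.9 percentage points lower from compound 3 to compound 4 (beyond the scatter), placed beside a number 19.5 percentage points lower from compound 1 to compound 2 (beyond the scatter) because that is the one chloro step measured and because compound 3 starts from 98.9%, close to compound 1. Compound 4 is thus estimated at 82%, with an expected range from 64% to 100%.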

Compound 4, a percentage reported as activity, at one concentration (the size of the read-out at that concentration, not a potency): 67.6%
Compound 4: the middle estimate sits 14.4 percentage points above what was measured; the measured number falls inside the stated range.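

In this assay, chloro in place of hydrogen on an aromatic carbon gives a number 31.3 percentage points lower from compound 3 to compound 4 (beyond the scatter), and the earlier chloro step on the other core does not separate from it: the same change on two cores in this assay, a number 19.5 percentage points lower (beyond the scatter) from compound 1 to compound 2 and a number 31.3 percentage points lower (beyond the scatter) from compound 3 to compound 4, 11.8 percentage points apart, within the scatter of two such steps Across these two cores the change therefore points the same way, both steps lie beyond the scatter, and no difference in their size can be claimed. Within the data shown here, this does not show that the step carries over as a fixed amount, since there are only two pairs and the chloro does not stand at the same place in both: in compound 4 it sits two atoms from the ring nitrogen, para to a large group, so any contribution of the core cannot be told apart from that of the chloro's place.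

From the compounds shown here alone, it remains open whether chloro at one fixed place gives a matching step on both cores, and whether another group at these places, such as fluoro, trifluoromethyl, an amine or a carboxylic acid, would go the same way. Also open is how the read-out responds when the methoxy group gives way to a longer alkoxy chain, and the single concentration tested gives no potency for any of these compounds.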